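The source may hold more compounds than are shown below. What is called first, only, known or untested is meant among the compounds shown, and "the series" means these compounds.

In a functional assay on DU-145 cells (Homo sapiens) for antiproliferative activity, read by propidium iodide staining, with a stated time of 96 h (a lower number here means a stronger inhibitor, a higher number a weaker inhibitor), compound 1 (`CC(O)(CSc1ccc(S(F)(F)(F)(F)F)cc1)C(=O)Nc1cccc(S(F)(F)(F)(F)F)c1`) gives 24800 nM and compound 2 (`CC(O)(CSc1ccc(F)cc1)C(=O)Nc1cccc(S(F)(F)(F)(F)F)c1`) gives 38500 nM. These two values lie within the scatter of each other, so the numbers do not separate compound 2 from compound 1.

Compound 3 (`CC(O)(CSc1cccc(C(F)(F)F)c1)C(=O)Nc1cccc(S(F)(F)(F)(F)F)c1`) keeps the core of compound 2 and changes only the group on the sulfur, with 3-(trifluoromethyl)phenyl in place of 4-fluorophenyl on a sulfur.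

For the measured compounds named here, one measured step bears on this change, as compound 1 and compound 2 also differ in the group carried on that sulfur. That step, a 1.6-fold higher number from compound 1 to compound 2 (0.19 log units; within the scatter), stays within the scatter, even though a single fluorine takes the place of a larger group. Going by the values given here, it is only one step, and no measured compound yet carries a trifluoromethyl group. On this thin evidence, no step beyond the scatter is expected in this assay, and no direction is clearly favoured.

The estimate therefore means a 1.3-fold lower number from compound 2 to compound 3 (0.11 log units; within the scatter). For compound 3 the estimated value is 30000 nM, with an expected range from 12000 nM to 70000 nM.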

Compound 3, half-maximal inhibitory concentration: 19100 nM
The estimate for compound 3 lay 1.6-fold (0.20 log units) above the measured number; the range from low to high includes it.
By their numbers in this assay, from the lowest: compounds 3, 1 and 2 (each within the scatter of the next).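

With compound 3, this assay gives a second reading at this position, now for a change that also enlarges the group on the sulfur, from 7 to 10 heavy atoms, and replaces 4-fluorophenyl with 3-(trifluoromethyl)phenyl: a 2.0-fold lower number from compound 2 to compound 3 (0.30 log units; within the scatter). Taken with a 1.6-fold higher number from compound 1 to compound 2 (0.19 log units; within the scatter), this means that both listed steps on this sulfur stay within the scatter, so the three aryl groups shown do not separate the compounds, and the range of groups tolerated here without a step beyond the scatter is wider than a single pair could show. No measurement offered here explains why these exchanges leave the numbers so close together.

The compounds shown leave open whether an amine or a carboxylic acid on this aromatic ring, or a longer chain on the sulfur in place of the ring, would give a step beyond the scatter. On these data alone, all three compounds also share the rest of the core, so what a change elsewhere in it would do to the antiproliferative numbers also remains open.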